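The source may report more compounds than this note shows. Statements on the series, on what has been measured and on what is new or still open speak of the compounds shown alone.

Measured so far:
compound 1 `Cc1nc2ccccc2n1CCCCN1CCN(C(c2ccccc2)c2ccccc2)CC1`: in an assay on RPMI-8226 cells for antagonist activity at P2X purinoceptor 7 (Homo sapiens), read by calcium flux (a lower number here means a stronger inhibitor, a higher number a weaker inhibitor), compound 1 gives 850 nM.
compound 2 `Cc1ccc2ccn(CCCCN3CCN(C(c4ccccc4)c4ccccc4)CC3)c2c1`: compound 2 gives 6500 nM.
compound 3 `COc1ccc2c(ccn2CCCCN2CCN(C(c3ccccc3)c3ccccc3)CC2)c1`: compound 3 gives > 10000 nM, a limit of the assay and not a number.

Compound 3 thus stands at the weak end of the three, sitting at the limit (the limit of > 10000 nM in this assay, at which 1 of the 3 values shown sits). Compound 4 `c1ccc(-c2nnnn2CCCCN2CCN(C(c3ccccc3)c3ccccc3)CC2)cc1` differs from compound 3 by 5-phenyl-1H-tetrazol-1-yl in place of 5-methoxy-1H-indol-1-yl on a saturated chain carbon, four bonds along the chain from an amine nitrogen in a ring. The steps that lead into compound 3 are an at least 11-fold higher number from compound 1 to compound 3 (1.07 log units; beyond the scatter) and an at least 1.5-fold higher number from compound 2 to compound 3 (0.18 log units; that floor lies within the scatter); neither involves the entering group, so they fix the direction only loosely, though compound 1 with its own azole-type ring gives the lowest number of the three. A return toward a measurable value is expected, an at least 3.3-fold lower number from compound 3 to compound 4 (0.52 log units; beyond the scatter). Compound 4 is estimated at 3000 nM, range 600 nM to 10000 nM.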

Compound 4, half-maximal inhibitory concentration: 3200 nM
Beside the measured number, compound 4's estimate is 1.1-fold (0.03 log units) below it; the measured number falls inside the stated range.
By their numbers in this assay, from the lowest: compound 1; then compound 4; then compound 2. At a limit, above all of these: compound 3.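

Compound 3 is a limit of the assay and not a number: the limit of > 10000 nM in this assay, at which 1 of the 4 values shown sits.

At this position in this assay, 5-phenyl-1H-tetrazol-1-yl gives an at least 3.1-fold lower number from compound 3 to compound 4 (0.49 log units; beyond the scatter), and the same group gives a 2.0-fold lower number from compound 2 to compound 4 (0.31 log units; beyond the scatter). The 2-methyl-1H-benzimidazol-1-yl group still holds the lower number, with a 3.8-fold higher number from compound 1 to compound 4 (0.58 log units; beyond the scatter), so compound 1 goes against any ordering by the count of hetero atoms in the five-membered ring.

From the compounds shown here alone, how an amine, a carboxylic acid or a longer chain would read at this position stays open. Going by these compounds, the shared core is constant in all four compounds, so its contribution also stays open.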